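Swapping Propyl for Cyclopropyl on the Shared Core

The source may hold more compounds than are shown below. What is called first, only, known or untested is meant among the compounds shown, and "the series" means these compounds.

Of the compounds shown here, two have so far been measured in a functional assay on CHO cells for antagonist activity at prostaglandin E2 receptor EP4 subtype (Homo sapiens), read by calcium flux, with a stated time of 15 min; a higher number here means a weaker inhibitor, a lower number a stronger inhibitor. Compound 1 `C[C@H](NC(=O)c1cnnn1Cc1ccc(C(F)(F)F)cc1)c1ccc(C(=O)O)cc1` carries hydrogen on the aromatic carbon of its five-membered ring, and in this assay compound 1 reaches only the assay limit of > 10000 nM rather than a number. Compound 2 `CCCc1nnn(Cc2ccc(C(F)(F)F)cc2)c1C(=O)N[C@@H](C)c1ccc(C(=O)O)cc1` carries propyl at that same carbon, and in this assay compound 2 gives 68.8 nM. Within the data shown here, the step of an at least 140-fold lower number from compound 1 to compound 2 (2.16 log units; beyond the scatter) is the only measured change, and it is large; with compound 1 sitting at the limit (the limit of > 10000 nM in this assay, at which 1 of the 2 values shown sits), its true size can only be stated as a lower bound. Among the measured compounds shown here, compound 2 thus holds the only real number in this small set.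

Compound 3 `C[C@H](NC(=O)c1c(C2CC2)nnn1Cc1ccc(C(F)(F)F)cc1)c1ccc(C(=O)O)cc1` introduces the change (cyclopropyl in place of propyl on an aromatic carbon), exchanging one three-carbon group for another. For the measured compounds named here, no measured step bears directly on this exchange: the one measured step compares a carbon group against hydrogen, not two carbon groups against each other. A step beyond the scatter is therefore not expected. Compound 3 is estimated at 70 nM, with a range from 25 nM to 200 nM, which means an expected step of a 1.0-fold higher number from compound 2 to compound 3 (0.01 log units; within the scatter).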

Compound 3, half-maximal inhibitory concentration: 52.1 nM
Compound 3: the middle estimate sits 1.3-fold (0.13 log units) above what was measured; the measured number falls inside the stated range.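

In this assay, the exchange of the open propyl chain for the cyclopropyl ring, each with 3 carbon heavy atoms, gives a 1.3-fold lower number from compound 2 to compound 3 (0.12 log units; within the scatter), so this position does not separate these two groups. Measured against hydrogen at the same carbon, the ring gives an at least 190-fold lower number from compound 1 to compound 3 (2.28 log units; beyond the scatter), a large step like the one seen for propyl, an at least 140-fold lower number from compound 1 to compound 2 (2.16 log units; beyond the scatter), so the large step from hydrogen is not confined to an open chain. As far as these compounds go, the true size of both steps from compound 1 stays unknown, since compound 1 has a limit of the assay rather than a number: the limit of > 10000 nM in this assay, at which 1 of the 3 values shown sits.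

The compounds shown leave open whether a carbon group with fewer or more atoms, such as methyl or a longer chain like butyl, would give a number close to those of compound 2 and compound 3, and whether a group containing other atoms, such as an amine or a methoxy group, could take the same place. They also leave open whether the two groups would stay this close in any read-out other than this assay.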